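The source may report more compounds than this note shows. Statements on the series, on what has been measured and on what is new or still open speak of the compounds shown alone.

Series notes on the shared core of compound 1. Compound 1 `Cc1ccc([C@]2(CO)NC[C@@H](O)[C@@H]2O)cc1` and compound 2 `CCCCCCCCC[C@]1(CO)NC[C@@H](O)[C@@H]1O` are the measured members. In an assay on isolated protein for inhibition of alpha-mannosidase (Canavalia ensiformis), tested at 1000 uM (a higher number here means more inhibition at the concentration tested (going by the name of the read-out), a lower number less inhibition), compound 1 gives 0%. In this assay compound 2 gives 0%, level with compound 1 at the digits reported and within the scatter. Compound 3 `CCCC[C@]1(CO)NC[C@@H](O)[C@@H]1O` is not yet measured. Relative to compound 2: hydrogen in place of pentyl on a saturated chain carbon, four bonds along the chain from a saturated ring carbon. Going by the values given here, no measured pair here follows this change, and compounds 1 and 2 together give no sign of movement in this assay. The expected step is no change at the digits printed from compound 2 to compound 3 (within the scatter), none beyond the scatter. Compound 3 is estimated at 0%, range 0% to 12%.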

Compound 3, a percentage reported as inhibition, at one concentration (the size of the read-out at that concentration, not a potency): 1.9%
For compound 3 the middle estimate is 1.9 percentage points below the measured one; the range from low to high includes it.
By their numbers in this assay, from the lowest: compounds 1, 2 and 3 (each within the scatter of the next).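

Hydrogen in place of pentyl on a saturated chain carbon, four bonds along the chain from a saturated ring carbon, gives the first one-place comparison in the series: in this assay the step is a number 1.9 percentage points higher from compound 2 to compound 3 (within the scatter). Shortening the chain by this much therefore leaves the reading within the scatter at the concentration tested, though with all readings so close to nothing, this pair cannot show what the chain contributes.

Going by these compounds, whether an amine, a carboxylic acid or a longer chain in place of the butyl chain of compound 3 would give a reading beyond the scatter in this assay stays open. No data at hand bear on this result.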